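A few compounds are considered here, and "the series" means these few. Any claim that something is new, unique, unknown or untested is made for them only; others in the source may bear on it.

compound 1 `O=C(CCC1C(=O)N(c2ccc(Cl)cc2)C(=O)N1Cc1ccc(Br)cc1)Nc1ccc(C(=O)NO)cc1`: 9.7 nM
compound 2 `O=C(CCC1C(=O)N(c2ccc(Cl)cc2)C(=O)N1Cc1ccc(Br)cc1)NCc1ccc(C(=O)NO)cc1`: 16.5 nM

In an assay on isolated protein for inhibition of protein deacetylase HDAC6 (Homo sapiens), read by fluorescence, with stated times of 5 min and 60 min (on this read-out higher numbers stand for weaker inhibition and lower numbers for stronger inhibition), compound 1 gives 9.7 nM, the lowest of the two numbers; compound 2 sits within the scatter of it, a 1.7-fold higher number from compound 1 to compound 2 (0.23 log units; within the scatter). Compound 3 `CN1C(=O)N(c2ccc(Cl)cc2)C(=O)C1CCC(=O)Nc1ccc(C(=O)NO)cc1` differs from compound 1 by hydrogen in place of 4-bromophenyl on a saturated chain carbon bound to an amide-type nitrogen in a ring. For the measured compounds named here, no measured step touches this position: the single known step, between compound 1 and compound 2, alters the amide end of the molecule and does not bear on it. Without a guide from the series, compound 3 is expected to come out weaker, a 3.1-fold higher number from compound 1 to compound 3 (0.49 log units; beyond the scatter). Compound 3 is estimated at 30 nM, between 8 nM and 120 nM.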

Compound 3, half-maximal inhibitory concentration: 7 nM
Estimate against measurement, compound 3: 4.3-fold (0.63 log units) above; measured number outside the range, below it.
By their numbers in this assay, from the lowest: compounds 3, 1 and 2 (each within the scatter of the next, the first and the last beyond it).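

At this position, the 4-bromobenzyl of compound 1 can give way to methyl with no change beyond the scatter in this assay (a 1.4-fold lower number from compound 1 to compound 3 (0.14 log units; within the scatter)). The 4-bromophenyl, with its one six-membered aromatic ring and 7 heavy atoms, is therefore not required for this level of inhibition in the series. Nothing available explains this tolerance.

Going by these compounds, whether an amine or a carboxylic acid at this position would also hold the value remains open. So does whether the 4-(hydroxycarbamoyl)benzyl of compound 2 would behave the same with methyl in place of 4-bromobenzyl.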